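A few compounds are considered here, and "the series" means these few. Any claim that something is new, unique, unknown or untested is made for them only; others in the source may bear on it.

Working notes on the series. Three compounds carry numbers in a physicochemical assay for lipophilicity, at pH 7.4; a higher number here means a more lipophilic compound, a lower number a more polar compound. Compound 1 `CNC(=O)c1cc(C(=O)NC2CC2)cn(Cc2ccc(F)cc2)c1=O` gives 3.2 in this assay, the second highest of the three. Compound 2 `CCNC(=O)c1cc(C(=O)NC)c(=O)n(Cc2ccccc2)c1` gives 3, a number within the scatter of compound 1, so the two are not separated. Compound 3 `CCNC(=O)c1cccn(Cc2ccccc2)c1=O` gives 3.7, beyond the scatter above compound 1. Among the measured compounds shown here, no single-point step between measured compounds is available.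

Compound 4 `CNC(=O)c1cc(C(=O)NC2CC2)cn(CC2CCCOC2)c1=O` is unmeasured and differs from compound 1 as follows: oxan-3-yl in place of 4-fluorophenyl on a saturated chain carbon bound to an aromatic nitrogen. For the measured compounds named here, for compound 4 the step of a number 1.00 log units lower from compound 1 to compound 4 (beyond the scatter) is expected to run downward, beyond the scatter, with no measured pair to calibrate its size. Compound 4 is therefore estimated at 2.2, within 1.6 to 2.8, pending measurement.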

Compound 4, distribution coefficient: 2
The estimate for compound 4 lay 0.20 log units above the measured number; measured number inside the range.
By their numbers in this assay, from the lowest: compound 4; then compounds 2 and 1 (each within the scatter of the next); then compound 3.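

In this assay the series now holds its first step with a single change: oxan-3-yl in place of 4-fluorophenyl on a saturated chain carbon bound to an aromatic nitrogen gives a number 1.20 log units lower from compound 1 to compound 4 (beyond the scatter) and this step is large. This position is thus the first shown to move the number on its own, with the rest of compound 1 unchanged. Nothing in hand tells what lies behind the step.

On these data alone, whether the ring oxygen of oxan-3-yl or the loss of the 4-fluorophenyl ring carries the step stays open. So does how an amine, a carboxylic acid or a longer chain would read at this place.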